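A few compounds are considered here, and "the series" means these few. Any claim that something is new, unique, unknown or untested is made for them only; others in the source may bear on it.

Compound 2 `CCCCC(=O)NCC(=O)N(C)c1ccc(Cl)cc1C(=O)c1ccccc1Cl` gives 90 mg/kg in a functional assay on the whole organism with Mus musculus as the target, in the rotarod test (on this read-out lower numbers stand for an effect already at smaller amounts and higher numbers for an effect only at larger amounts of compound), and compound 1 `CCCC(=O)NCC(=O)N(C)c1ccc(Cl)cc1C(=O)c1ccccc1Cl` gives 55.2 mg/kg in this assay. Among the compounds with values here, the only measured step, a 1.6-fold higher number from compound 1 to compound 2 (0.21 log units; within the scatter), separates these two, so compound 2 sits at the end of a pair that does not differ beyond the scatter. Compound 3 `CC(=O)NCC(=O)Nc1ccc(Cl)cc1C(=O)c1ccccc1Cl` reaches only a limit of the assay, > 100 mg/kg. Compound 4 `CC(C)NCC(=O)NCC(=O)N(C)c1ccc(Cl)cc1C(=O)c1ccccc1Cl` differs from compound 2 by isopropylamino in place of propyl on a saturated chain carbon bound to a carbonyl carbon. Within the data shown here, no measured step brings an amine into the chain, so the one step at hand, a change of chain length within the scatter, gives little to go on. Compound 4 is therefore expected to show a step of a 1.1-fold higher number from compound 2 to compound 4 (0.05 log units; within the scatter), an estimated 100 mg/kg with a range from 40 mg/kg to 250 mg/kg.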

Compound 4, dose for half-maximal effect: 13 mg/kg
Compound 4: the middle estimate sits 7.7-fold (0.89 log units) above what was measured; the measured number lies below the stated range.
By their numbers in this assay, from the lowest: compound 4; then compounds 1 and 2 (each within the scatter of the next). At a limit, above all of these: compound 3.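

In this assay, within the data shown here, isopropylamino in place of propyl on a saturated chain carbon bound to a carbonyl carbon gives a 6.9-fold lower number from compound 2 to compound 4 (0.84 log units; beyond the scatter) and is the first change here that lies beyond the scatter. Isopropylamino in place of ethyl at the same place gives a 4.2-fold lower number from compound 1 to compound 4 (0.63 log units; beyond the scatter) and points the same way, so this position responds to the amine far more than to chain length. Nothing shown accounts for the size of these steps. Going by these compounds, whether a primary amine, a dimethylamino group or a cyclic amine would do the same at this position stays open.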